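Amide series: carboxy to carbamoyl step on the side chain

This account rests on a few compounds, and the source may have more. Where it says the series, first, only, none or still open, it means among the compounds named here.

compound 1 `CC[C@H](C)[C@H](NC(=O)CN(c1ncnc2c1ncn2C1CCCCO1)C1CC1)C(=O)OCc1ccccc1` — 25.6%
compound 2 `O=C(O)CC[C@H](NC(=O)CN(c1nc(Cl)nc2[nH]cnc12)C1CC1)C(=O)O` — 26.8%

Both were run in a functional assay on the whole organism (Tail, strain ICR) with Mus musculus as the target, in the tail flick test, with a stated time of 30 min, at a dose of 25 umol/kg by the oral route; on this read-out lower numbers stand for a weaker effect and higher numbers for a stronger effect at the one dose given. Compound 1 gives 25.6% and compound 2 gives 26.8%; the two values lie within the usual scatter of each other, so no order is read between them. Compound 3 `NC(=O)CC[C@H](NC(=O)CN(c1nc(Cl)nc2[nH]cnc12)C1CC1)C(=O)O` differs from compound 2 by amino in place of hydroxy on a carbonyl carbon; cut one bond further out, the change reads carboxy to carbamoyl. Among the compounds with values here, no measured pair shows this change, so its size is unknown here. The step expected is a number 0.2 percentage points higher from compound 2 to compound 3 (within the scatter), none beyond the scatter in either direction. For compound 3 the expected value is 27%, between 12% and 45%.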

Compound 3, a percentage reported as activity, at one dose (the size of the read-out at that dose, not a potency): 33.1%
Beside the measured number, compound 3's estimate is 6.1 percentage points below it; the range from low to high includes it.
By their numbers in this assay, from the lowest: compounds 1, 2 and 3 (each within the scatter of the next).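

In this assay, the change from 2-carboxyethyl to 2-carbamoylethyl gives a number 6.3 percentage points higher from compound 2 to compound 3 (within the scatter), so amino can stand in place of hydroxy on this carbonyl carbon with no step beyond the scatter. The side-chain carboxy is therefore not required for the effect at this single dose. Nothing at hand bears on the reason for this result. Still open, going by these compounds, is whether a methyl ester, a nitrile or a longer chain at this position would stay within the scatter of compound 2. On these data alone, a dose-response relationship for these compounds also remains open.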